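Dropping the trifluoromethoxy group from compound 3

The compounds below may be only part of what the source reports. "The series", "measured", "known", "first", "only" and "open" are said of these compounds alone.

In a functional assay on HCT-116 cells (Homo sapiens) for cytotoxicity (a higher number here means that more compound is needed for the effect, a lower number that less compound is needed), compound 1 (`CC(=O)SCC(=O)c1ccc(C(=O)Nc2ccc(OC(F)(F)F)cc2)cc1`) stands at "not determined" (no result reported) and compound 2 (`CC(=O)SCC(=O)c1ccc(NC(=O)Nc2ccc(OC(F)(F)F)cc2)cc1`) at "not determined" (no result reported) with no number to compare. Going by the values given here, compound 3 (`CC(=O)SCC(=O)c1ccc(NS(=O)(=O)c2ccc(OC(F)(F)F)cc2)cc1`) gives 8800 nM as the only number, so it holds no rank. Compound 4 (`CC(=O)SCC(=O)c1ccc(NS(=O)(=O)c2ccccc2)cc1`) carries hydrogen in place of trifluoromethoxy on an aromatic carbon. Among the compounds with values here, no measured step informs this change, so the reasoning starts from compound 3 at 8800 nM alone. A modest rise in this assay is expected, possibly no larger than the scatter. The estimate is a 1.6-fold higher number from compound 3 to compound 4 (0.20 log units; within the scatter) at its middle. Compound 4 is expected at 14000 nM (estimated range 5000 nM to 40000 nM).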

Compound 4, half-maximal effective concentration: 15400 nM
Compound 4: the middle estimate sits 1.1-fold (0.04 log units) below what was measured; the range from low to high includes it.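

In this assay, hydrogen in place of trifluoromethoxy on an aromatic carbon, para to a large group, gives a 1.8-fold higher number from compound 3 to compound 4 (0.24 log units; within the scatter). Going by these compounds alone, this is the first readable step: at this position, the trifluoromethoxy group and hydrogen cannot be told apart in this read-out. No independent data bear on this result.

Open, from the compounds shown here alone, is whether an amine or a carboxylic acid at this position would give a step beyond the scatter. One step at one position also says nothing about the rest of the core.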